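The source may report more compounds than this note shows. Statements on the series, on what has been measured and on what is new or still open speak of the compounds shown alone.

Compound 3 `COc1cc(-c2nnc(SCC(=O)c3ccccc3F)n2N)cc(OC)c1OC` is one of three measured compounds that share one core and differ only in the group on the carbonyl carbon. In a functional assay on HepG2 cells (Homo sapiens) for antiproliferative activity, read by MTT assay, with a stated time of 48 h (a higher number here means a weaker inhibitor, a lower number a stronger inhibitor), compound 1 `COc1cc(-c2nnc(SCC(=O)c3ccccc3)n2N)cc(OC)c1OC` gives 7800 nM, compound 2 `COc1cc(-c2nnc(SCC(=O)c3ccc(Br)cc3)n2N)cc(OC)c1OC` gives 92500 nM and compound 3 gives 22600 nM, which places compound 3 second highest of the three. Compound 4 `COc1cc(-c2nnc(SCC(=O)NCc3ccc(Cl)cc3)n2N)cc(OC)c1OC` carries (4-chlorobenzyl)amino in place of 2-fluorophenyl on a carbonyl carbon. For the measured compounds named here, no measured step exchanges the group on the carbonyl carbon for a (4-chlorobenzyl)amino group; the steps that touch this place, a 2.9-fold higher number from compound 1 to compound 3 (0.46 log units; beyond the scatter) and a 4.1-fold lower number from compound 2 to compound 3 (0.61 log units; beyond the scatter), were modest and ran in opposite directions. A modest step is therefore expected, more likely upward, a 1.5-fold higher number from compound 3 to compound 4 (0.19 log units; within the scatter). Compound 4 is estimated at 35000 nM, within 8000 nM to 150000 nM.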

Compound 4, half-maximal inhibitory concentration: > 100000 nM
Compound 4: only a limit was reported; the forecaster's own chance of this, stated with the estimate: 10%; at least 2.8-fold (0.45 log units) between middle value and limit.
By their numbers in this assay, from the lowest: compound 1; then compound 3; then compound 2. At a limit, above all of these: compound 4.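

In this assay compound 4 gives only a limit, > 100000 nM. The earlier compounds shown here changed only a substituent on the phenyl ring, whereas this change replaces the whole aryl group with (4-chlorobenzyl)amino, bringing a nitrogen and a hydrogen-bond donor, and gives an at least 4.4-fold higher number from compound 3 to compound 4 (0.64 log units; beyond the scatter), an at least 1.0-fold higher number from compound 2 to compound 4 (0.03 log units; that floor lies within the scatter) and an at least 12-fold higher number from compound 1 to compound 4 (1.10 log units; beyond the scatter). Thus all three changes from compound 1 raise the number, although the floor of the step from compound 2 to compound 4 lies within the scatter.

Going by these compounds, whether the nitrogen link or the chlorine matters more remains open. A plain benzylamino group or a morpholine on the carbonyl carbon would help separate them.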